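From compound 3 to compound 4: an untested ring exchange

The compounds below may be only part of what the source reports. "The series", "measured", "known", "first", "only" and "open" are said of these compounds alone.

In an ADME assay on Caco-2 cells (Homo sapiens) for permeability, read by LC-MS, with a stated time of 2 h, at pH 7.4, tested at 10 uM (on this read-out higher numbers stand for higher permeability and lower numbers for lower permeability), compound 1 `CC(C)c1nnc2n1C[C@H](C)N(C(=O)c1cccc(C(F)(F)c3n[nH]c(=O)c4ccccc34)c1)C2` gives 2 10^-6 cm/s and compound 2 `C[C@H]1Cn2c(Br)nnc2CN1C(=O)c1cccc(C(F)(F)c2n[nH]c(=O)c3ccccc23)c1` gives 12.1 10^-6 cm/s. Compound 3 `O=C(c1cccc(Cc2n[nH]c(=O)c3ccccc23)c1)N1CCn2c(nnc2C(F)(F)F)C1` gives 1.3 10^-6 cm/s, within the scatter of compound 1 and well short of compound 2. Compound 4 `O=C(c1cccc(Cc2n[nH]c(=O)c3c2CCCC3)c1)N1CCn2c(nnc2C(F)(F)F)C1` differs from compound 3 by a group of 11 heavy atoms (8 carbon, 2 nitrogen, 1 oxygen; one six-membered non-aromatic ring of carbon only, one six-membered aromatic ring with 2 hetero atoms) in place of a group of 11 heavy atoms (8 carbon, 2 nitrogen, 1 oxygen; one six-membered aromatic ring of carbon only, one six-membered aromatic ring with 2 hetero atoms), on a saturated chain carbon bound to an aromatic carbon. Going by the values given here, the only measured step, a 6.1-fold higher number from compound 1 to compound 2 (0.78 log units; beyond the scatter), is modest and beyond the scatter, but it is bromo in place of isopropyl, a different exchange. Among the compounds with values here, no measured step therefore tests this change, and no shift beyond the scatter is expected in this assay. The estimated outcome is a 1.2-fold higher number from compound 3 to compound 4 (0.06 log units; within the scatter). Compound 4 is expected at 1.5 10^-6 cm/s, with an estimated range from 0.6 10^-6 cm/s to 3.5 10^-6 cm/s.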

Compound 4, apparent permeability: 0.4 10^-6 cm/s
Estimate against measurement, compound 4: 3.8-fold (0.57 log units) above; the measured number lies below the stated range.
By their numbers in this assay, from the lowest: compound 4; then compounds 3 and 1 (each within the scatter of the next); then compound 2.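

Replacing the six-membered aromatic ring of carbon only with a six-membered non-aromatic ring of carbon only, on a saturated chain carbon bound to an aromatic carbon, registers in this assay as a 3.3-fold lower number from compound 3 to compound 4 (0.51 log units; beyond the scatter). The read-out therefore responds to this ring exchange, which the earlier bromo and isopropyl step could not show. Nothing available explains the drop. The compounds shown leave open how a pyridine or thiophene ring in place of the ring of carbon only would read, and whether the exchange gives a similar step on other compounds.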